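The compounds below may be only part of what the source reports. "The series", "measured", "known", "first", "only" and "open" are said of these compounds alone.

Measured compounds:

Compound 1, `COc1cc2ncnc(NCc3cccc(NC(=O)Nc4ccccc4C)c3)c2cc1OC`: in a functional assay on HepG2 cells (Homo sapiens) for antiproliferative activity, read by MTT assay (a lower number here means a stronger inhibitor, a higher number a weaker inhibitor), compound 1 gives > 50000 nM, a limit of the assay rather than a number.

Compound 2, `COc1cc2ncnc(NCc3cccc(NC(=O)Nc4cccc(C)c4)c3)c2cc1OC`: in this assay compound 2 gives 21500 nM.

Compound 2 therefore holds the only number shown in this assay; the other value is the limit of > 50000 nM in this assay, at which 1 of the 2 values shown sits. For the measured compounds named here, the single measured step, an at least 2.3-fold lower number from compound 1 to compound 2 (0.36 log units; beyond the scatter), exchanges one methylphenyl group for another on the amide-type nitrogen of the urea and lowers the number by an amount that is judged beyond the scatter.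

Compound 3, `COc1ccc(NC(=O)Nc2cccc(CNc3ncnc4cc(OC)c(OC)cc34)c2)cc1`, has not yet been measured. It differs from compound 2 in one place: 4-methoxyphenyl in place of 3-methylphenyl on an amide-type nitrogen. Going by the values given here, no measured step exchanges a methyl group for a methoxy group, so the only step available speaks to it just loosely, showing that a change on this phenyl ring can shift the number in this assay by a modest amount. With that thin basis, no shift beyond the scatter is expected, and compound 3 is estimated at 20000 nM, within 6000 nM to 50000 nM, which means an expected step of a 1.1-fold lower number from compound 2 to compound 3 (0.03 log units; within the scatter).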

Compound 3, half-maximal inhibitory concentration: > 50000 nM
Compound 3: a limit, no number; the forecaster's own chance of this, stated with the estimate: 30%; at least 2.5-fold (0.39 log units) between middle value and limit.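

On the amide-type nitrogen of the urea, 4-methoxyphenyl in place of 3-methylphenyl gives an at least 2.3-fold higher number from compound 2 to compound 3 (0.36 log units; beyond the scatter), so in this assay the number at this position responds not only to where a methyl group sits, as the earlier pair showed, but also to an exchange of the group itself. The true size of this step is not known, since compound 3 gives > 50000 nM, which is a limit of the assay and not a number. Compound 1 and compound 3 cannot be read against each other, because both stop at the same limit, leaving compound 2 as the only one with a number: the limit of > 50000 nM in this assay, at which 2 of the 3 values shown sit.

This exchange alters both the group and its place on the ring, so the compounds shown cannot separate the two, and a methoxy group placed as the methyl group of compound 2 is placed would be needed to do so. As far as these compounds go, it also remains open whether an amine or a carboxylic acid on this ring would give a lower number than compound 2, which gives 21500 nM.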